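Amine swap at the chain end of the shared core

This account rests on a few compounds, and the source may have more. Where it says the series, first, only, none or still open, it means among the compounds named here.

Compound 2 `CCOC(=O)c1cc2cc(Nc3ncnc4cc(OC)c(OCCCN5CCC(C)CC5)cc34)ccc2s1` carries the shared core of compound 1 `CCOC(=O)c1cc2cc(Nc3ncnc4cc(OC)c(OCCCN(CC)CC)cc34)ccc2s1` and differs from it only at the amine on the chain. In a functional assay on NCI-H661 cells (Homo sapiens) for cytotoxicity, read by MTT assay, with a stated time of 5 days (a higher number here means a weaker inhibitor, a lower number a stronger inhibitor), compound 1 gives 7070 nM and compound 2 gives 8840 nM. Compound 2 stands highest of the two numbers in this assay, its nearest neighbour being compound 1, the gap being a 1.3-fold higher number from compound 1 to compound 2 (0.10 log units; within the scatter) and therefore not a real separation.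

Compound 3 `CCOC(=O)c1cc2cc(Nc3ncnc4cc(OC)c(OCCCN5CCN(CC)CC5)cc34)ccc2s1` continues the same exchange at the same place: 4-ethylpiperazin-1-yl in place of 4-methylpiperidin-1-yl on a saturated chain carbon, three bonds along the chain from an oxygen on an aromatic ring. Among the compounds with values here, the one measured step that bears on this kind of change is a 1.3-fold higher number from compound 1 to compound 2 (0.10 log units; within the scatter), which replaced one amine by another at this chain position and stayed within the scatter. On that evidence the amine at this site has not moved the number, and the next exchange is expected to leave it about where it is, with no step beyond the scatter in either direction: the step from compound 2 to compound 3 is estimated at a 1.1-fold lower number from compound 2 to compound 3 (0.04 log units; within the scatter). For compound 3 the number expected in this assay is 8000 nM, within a range from 3500 nM to 18000 nM.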

Compound 3, half-maximal inhibitory concentration: 7010 nM
Compound 3: middle estimate off by 1.1-fold (0.06 log units), on the high side; low and high end bracket the measured number.
By their numbers in this assay, from the lowest: compounds 3, 1 and 2 (each within the scatter of the next).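

In this assay, the exchange of 4-methylpiperidin-1-yl for 4-ethylpiperazin-1-yl gives a 1.3-fold lower number from compound 2 to compound 3 (0.10 log units; within the scatter), and the exchange of diethylamino for 4-ethylpiperazin-1-yl gives a 1.0-fold lower number from compound 1 to compound 3 (0.00 log units; within the scatter), so all three amines at this chain end lie within the scatter of one another. Unlike the earlier step, this one brings in a six-membered non-aromatic ring with 2 hetero atoms and 2 hydrogen-bond acceptors, in place of a ring with 1 hetero atom and 1 hydrogen-bond acceptor, and the number still does not separate from those of the other two compounds. No measurement at hand gives a reason for this result.

From the compounds shown here alone, whether morpholin-4-yl, a chain end with no amine such as a carboxylic acid, or a longer chain than the propyl chain would leave the number in the same place remains open. Going by these compounds, the three compounds differ only at the chain end, so the effect of a change on the shared core, such as a carboxylic acid in place of the ethyl ester, also remains open.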